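Phenethyl in place of 4-chlorophenyl on compound 3

This account rests on a few compounds, and the source may have more. Where it says the series, first, only, none or still open, it means among the compounds named here.

Measured in a functional assay on MOLT-4 cells (Homo sapiens); a higher number here means a weaker inhibitor, a lower number a stronger inhibitor:
- compound 1 `O=C(/C=C/c1ccc(Cl)c(Cl)c1)Oc1ccc(/C=C2\CCCCC2=O)cc1`: 47300 nM
- compound 2 `CN(C)CC1CCC/C(=C\c2ccc(OC(=O)/C=C/c3ccc(Br)cc3)cc2)C1=O`: 3060 nM
- compound 3 `O=C1CCCC/C1=C\c1ccc(OC(=O)c2ccc(Cl)cc2)cc1`: 38000 nM

Compound 3 lies within the scatter of compound 1, while compound 2 gives a lower number, beyond the scatter. Compound 4 `O=C(CCc1ccccc1)Oc1ccc(/C=C2\CCCCC2=O)cc1`, not yet measured, has phenethyl in place of 4-chlorophenyl on a carbonyl carbon. Compound 1 at 47300 nM and compound 3 at 38000 nM carry different groups there yet stay within the scatter, so no shift beyond the scatter is expected. The expected change, a 1.1-fold lower number from compound 3 to compound 4 (0.04 log units; within the scatter), is small and in no firm direction. For compound 4 the estimated value is 35000 nM, with an expected range from 15000 nM to 80000 nM.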

Compound 4, half-maximal inhibitory concentration: 31100 nM
Estimate against measurement, compound 4: 1.1-fold (0.05 log units) above; the measured number falls inside the stated range.
By their numbers in this assay, from the lowest: compound 2; then compounds 4, 3 and 1 (each within the scatter of the next).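

In this assay, among the compounds shown here, phenethyl in place of 4-chlorophenyl on a carbonyl carbon gives a 1.2-fold lower number from compound 3 to compound 4 (0.09 log units; within the scatter), so this is the first step measured directly at this position. Exchanging the chlorine-bearing group for an all-carbon one, with an aromatic ring in both, leaves the number within the scatter. No measured evidence bears on why this exchange makes so little difference.

The compounds shown leave open whether an amine or a carboxylic acid on this chain would move the number beyond the scatter. Compound 2 differs from the others in more than one place, so its lower number cannot be tied to any single group.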